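A few compounds are considered here, and "the series" means these few. Any claim that something is new, unique, unknown or untested is made for them only; others in the source may bear on it.

Measured so far in a functional assay on MGC-803 cells (Homo sapiens) for inhibition, read by sulforhodamine B assay; on this read-out higher numbers stand for weaker inhibition and lower numbers for stronger inhibition:
compound 1 `O=C1C=C(Nc2ccc(I)cc2)C(=O)c2c1nc1n2[C@H]2OC[C@@H](O)[C@H]2OC1` gives 1400 nM
compound 2 `Cc1ccc(NC2=CC(=O)c3nc4n(c3C2=O)[C@H]2OC[C@@H](O)[C@H]2OC4)cc1C` gives 860 nM
compound 3 `CCCc1ccc(NC2=CC(=O)c3c(nc4n3[C@H]3OC[C@@H](O)[C@H]3OC4)C2=O)cc1` gives 1920 nM

Compound 3 stands highest of the three numbers; its gap to compound 1 is within the scatter, while compound 2 sits beyond the scatter below it. Within the data shown here, the only measured step that changes the group on the amine nitrogen, a 1.6-fold lower number from compound 1 to compound 2 (0.21 log units; within the scatter), stays within the scatter. Compound 4 `O=C1C(Nc2ccccc2F)=CC(=O)c2c1nc1n2[C@H]2OC[C@@H](O)[C@H]2OC1` differs from compound 3 in one place: 2-fluorophenyl in place of 4-propylphenyl on an amine nitrogen. That single measured aryl swap bears on this step, and it was within the scatter, so no step beyond the scatter is expected in this assay for compound 4. Among the measured compounds shown here, the entering group has no measured counterpart; the range is therefore kept wide. Compound 4 is expected at 1400 nM, between 600 nM and 3500 nM, an expected step of a 1.4-fold lower number from compound 3 to compound 4 (0.14 log units; within the scatter).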

Compound 4, half-maximal inhibitory concentration: 2000 nM
The estimate for compound 4 lay 1.4-fold (0.15 log units) below the measured number, and the stated range covers the measured number.
By their numbers in this assay, from the lowest: compounds 2, 1, 3 and 4 (each within the scatter of the next, the first and the last beyond it).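

In this assay, 2-fluorophenyl in place of 4-propylphenyl on the amine nitrogen gives a 1.0-fold higher number from compound 3 to compound 4 (0.02 log units; within the scatter), so a second aryl swap at this position stays within the scatter. This swap loses the propyl chain and brings in fluorine, with 7 heavy atoms entering where 9 leave, yet no step beyond the scatter appears. No evidence on any property of these groups bears on this result.

Still open, as far as these compounds go, is whether a non-aryl group on this nitrogen, such as cyclohexyl or benzyl, or an aryl carrying a carboxylic acid or an amine, would give a step beyond the scatter.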